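Replacing 2-Ethylphenyl with 3-Methoxyphenyl on the Shared Core

A few compounds are considered here, and "the series" means these few. Any claim that something is new, unique, unknown or untested is made for them only; others in the source may bear on it.

Of the compounds shown here, three with a shared core have been tested in a functional assay (muscle tissue) with Cavia porcellus as the target; on this read-out lower numbers stand for an effect already at smaller amounts and higher numbers for an effect only at larger amounts of compound. Compound 1 `COC(=O)C1=C(C)N=C(C)/C(=C(\O)OC)C1c1ccc(I)cc1` gives 22900 nM in this assay, compound 2 `COC(=O)C1=C(C)N=C(C)/C(=C(\O)OC)C1c1ccc(Cl)cc1Cl` gives 640 nM, and compound 3 `CCc1ccccc1C1C(C(=O)OC)=C(C)N=C(C)/C1=C(\O)OC` gives 6.46 nM, the lowest of the three numbers. Its distance from the others is clear: there is a 99-fold lower number from compound 2 to compound 3 (2.00 log units; beyond the scatter) and a 3500-fold lower number from compound 1 to compound 3 (3.55 log units; beyond the scatter), both beyond the scatter. Compound 4 `COC(=O)C1=C(C)N=C(C)/C(=C(\O)OC)C1c1cccc(OC)c1` differs from compound 3 only in the aromatic ring on the saturated ring carbon: 3-methoxyphenyl in place of 2-ethylphenyl on a saturated ring carbon. Within the data shown here, no measured compound carries a 3-methoxyphenyl group, so the steps from compound 1 and compound 2 to compound 3 are the only ones that bear on this change, and they show that swapping this ring alone moves this assay by large amounts. Because compound 3 is set apart by a 99-fold lower number from compound 2 to compound 3 (2.00 log units; beyond the scatter), a step to a higher number is expected for compound 4, namely a 31-fold higher number from compound 3 to compound 4 (1.49 log units; beyond the scatter). Compound 4 is therefore estimated at 200 nM, with a range from 30 nM to 1500 nM.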

Compound 4, half-maximal effective concentration: 191 nM
Beside the measured number, compound 4's estimate is 1.0-fold (0.02 log units) above it; the measured number falls inside the stated range.
By their numbers in this assay, from the lowest: compound 3; then compound 4; then compound 2; then compound 1.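

In this assay, the step of a 30-fold higher number from compound 3 to compound 4 (1.47 log units; beyond the scatter) shows that the ring on this saturated ring carbon still moves the number strongly when the entering and leaving groups have the same number of heavy atoms, here with a hydrogen-bond acceptor entering in the 3-methoxyphenyl group. That group also gives lower numbers than both halogen-bearing rings, with a 3.4-fold lower number from compound 2 to compound 4 (0.53 log units; beyond the scatter) as a modest step and a 120-fold lower number from compound 1 to compound 4 (2.08 log units; beyond the scatter) as a large one, so among these four compounds the two rings without halogen give the lowest numbers. Nothing measured here explains these differences.

Compound 3 and compound 4 differ in both the group on the aromatic ring and its place there, and the compounds shown do not separate these two changes. They also leave open how this assay responds to an aromatic ring bearing an amine or a carboxylic acid, or to a longer chain in place of the ethyl group.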